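Swapping Chloro for Methoxy in a Weak Antiproliferative Pair

The compounds below may be only part of what the source reports. "The series", "measured", "known", "first", "only" and "open" are said of these compounds alone.

Compound 2 `Clc1ccc(C2=NN(c3ccc(-c4ccccc4)nn3)C(c3ccccc3)C2)cc1` stands at the weak end of the two numbers in hand: in a functional assay on Caco-2 cells (Homo sapiens) for antiproliferative activity, read by MTT assay, with a stated time of 24 h (a higher number here means a weaker inhibitor, a lower number a stronger inhibitor), compound 2 gives 100000 nM, the higher of the pair. For the measured compounds named here, its only neighbour, compound 1 `c1ccc(C2=NN(c3ccc(-c4ccccc4)nn3)C(c3ccccc3)C2)cc1`, in this assay gives 40900 nM. Going by the values given here, the single measured step, a 2.4-fold higher number from compound 1 to compound 2 (0.39 log units; beyond the scatter), shows that chloro in place of hydrogen on an aromatic carbon went along with a modest loss of potency. Compound 3 `COc1ccc(C2=NN(c3ccc(-c4ccccc4)nn3)C(c3ccccc3)C2)cc1` differs from compound 2 by methoxy in place of chloro on an aromatic carbon. Among the compounds with values here, no measured step speaks directly to this exchange; the one step in hand compares chloro with hydrogen, and it was modest. A step of comparable or smaller size in this assay is therefore expected, with the direction uncertain, so the expected step is a 1.5-fold lower number from compound 2 to compound 3 (0.19 log units; within the scatter). Compound 3 is estimated at 65000 nM in this assay, within 25000 nM to 150000 nM.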

Compound 3, half-maximal inhibitory concentration: > 100000 nM
Compound 3 was reported as a limit; the forecaster's own chance of this, stated with the estimate: 30%; middle value at least 1.5-fold (0.18 log units) away from the limit.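

Compound 3 is reported only as a limit in this assay, not as a number: the limit of > 100000 nM in this assay, at which 1 of the 3 values shown sits. Methoxy in place of hydrogen gives an at least 2.4-fold higher number from compound 1 to compound 3 (0.38 log units; beyond the scatter), so at this position, para to a large group, a loss of potency now goes with two different groups rather than with chloro alone. Methoxy in place of chloro gives a number no lower from compound 2 to compound 3 (the limit leaves the size open) and the size of this step cannot be read, and these two groups therefore cannot be ranked against each other.

On these data alone, whether any group at this position can improve on the hydrogen of compound 1 stays open, and an amine, a hydroxyl or a carboxylic acid placed there would put this to the test. Also open, as far as these compounds go, is whether changes elsewhere on the shared core would follow the same trend.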